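One Inverted Stereocentre: From Compound 2 to Compound 4

The compounds below may be only part of what the source reports. "The series", "measured", "known", "first", "only" and "open" are said of these compounds alone.

- Compound 1 `CC(=O)O[C@@]1(C)C/C=C2\O[C@H](C[C@@H]2C)C[C@]2(C)O[C@H]2C(=O)C(=C(C)C)CC1`: > 50000 nM (a limit)
- Compound 2 `CC(=O)O[C@@]1(C)CCC(=O)[C@H](C)CCC[C@]2(C)O[C@H]2C(=O)C(=C(C)C)CC1`: 44900 nM
- Compound 3 `CC(C)=C1CC[C@]2(C)CC[C@]3(O[C@H](C[C@H]3C)C[C@]3(C)O[C@H]3C1=O)O2`: > 50000 nM (a limit)

These three compounds were tested in a functional assay on PC-3 cells (Homo sapiens) for cytotoxicity, read by MTT assay, with a stated time of 24 h; on this read-out higher numbers stand for weaker inhibition and lower numbers for stronger inhibition. Compound 1 reads > 50000 nM, which is a limit of the assay and not a number. Compound 3 reads > 50000 nM, which is also a limit. Compound 2, at 44900 nM, is the only one of the three with an actual number, so it cannot be ranked against the other two.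

Compound 4 `CC(=O)O[C@@]1(C)CCC(=O)[C@@H](C)CCC[C@]2(C)O[C@H]2C(=O)C(=C(C)C)CC1` has not yet been measured. Its change from compound 2 is small: the two compounds have the same atoms and bonds and differ only in configuration as drawn: 1 of 4 stereo elements differ; a stereocentre at a saturated ring carbon is drawn R in compound 2 and S in compound 4. The same atoms are joined in the same way, and only the drawn configuration at that one carbon is inverted.

For the measured compounds named here, no measured pair here shows what such an inversion does in this assay, so the expectation rests on compound 2 at 44900 nM. No step beyond the usual scatter is expected, and neither direction is favoured. The expected change is a 1.1-fold higher number from compound 2 to compound 4 (0.03 log units; within the scatter), which is an estimate. For compound 4 the estimated value is 48000 nM, with an expected range from 20000 nM to 90000 nM.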

Compound 4, half-maximal inhibitory concentration: 24300 nM
Beside the measured number, compound 4's estimate is 2.0-fold (0.30 log units) above it; the measured number falls inside the stated range.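

Inverting the drawn configuration at this saturated ring carbon gives a 1.8-fold lower number from compound 2 to compound 4 (0.27 log units; within the scatter) in this assay, so this change at this position produces no step that can be told apart from repeat measurements. That step can be assigned to the one carbon alone, because nothing else in the structure changes: the fact that compounds 2 and 4 differ only in the configuration as drawn. For the compounds shown here, compound 1 and compound 3 could not show this, and their readings allow no such step to be read, because each of them is only a limit of the assay: the limit of > 50000 nM in this assay, at which 2 of the 4 values shown sit.

The pair shows only a single inversion at a single carbon in one cell line and at one stated time, so it leaves open whether the configuration at this carbon would matter in a compound with much stronger inhibition, or whether inverting another stereocentre of the shared core would behave the same way. Also open, going by these compounds, is what a free hydroxyl group or an amine in place of the acetate would do to the reading in this assay in either configuration.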